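From pentylsulfanyl to allylamino on the shared core

The compounds below may be only part of what the source reports. "The series", "measured", "known", "first", "only" and "open" are said of these compounds alone.

In a functional assay on HFF cells (Homo sapiens) for cytotoxicity (on this read-out lower numbers stand for higher toxicity in this test and higher numbers for lower toxicity in this test), compound 3 `CCCCCSc1nc(N)nc2c1ncn2/C=C1/C[C@@H]1CO` stands highest of the three measured compounds at 215000 nM against compound 1 `CCCCCOc1nc(N)nc2c1ncn2/C=C1/C[C@@H]1CO` at 41900 nM and compound 2 `COc1nc(N)nc2c1ncn2/C=C1/C[C@@H]1CO` at 15800 nM on the same scale. Compound 4 `C=CCNc1nc(N)nc2c1ncn2/C=C1/C[C@@H]1CO` is unmeasured and carries allylamino in place of pentylsulfanyl on an aromatic carbon in this comparison. Among the measured compounds shown here, no measured compound has allylamino. The steps bearing on it are a 5.1-fold higher number from compound 1 to compound 3 (0.71 log units; beyond the scatter) and a 14-fold higher number from compound 2 to compound 3 (1.13 log units; beyond the scatter) where pentylsulfanyl enters, with a 2.7-fold lower number from compound 1 to compound 2 (0.42 log units; beyond the scatter) as a smaller step without it. Losing pentylsulfanyl is therefore expected to bring a modest to large fall in this assay toward the other two values. The expected change is a 4.3-fold lower number from compound 3 to compound 4 (0.63 log units; beyond the scatter) as estimated here. For compound 4 the estimated value is 50000 nM within an estimated range of 15000 nM to 170000 nM in this test.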

Compound 4, half-maximal cytotoxic concentration: > 368000 nM
Compound 4 was reported as a limit; the forecaster's own chance of this, stated with the estimate: 20%; middle value at least 7.3-fold (0.86 log units) away from the limit.
By their numbers in this assay, from the lowest: compound 2; then compound 1; then compound 3. At a limit, above all of these: compound 4.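

Compound 4 is reported only as a limit in this assay: the limit of > 368000 nM in this assay, at which 1 of the 4 values shown sits. Allylamino on this aromatic carbon gives an at least 23-fold higher number from compound 2 to compound 4 (1.36 log units; beyond the scatter) and an at least 8.7-fold higher number from compound 1 to compound 4 (0.94 log units; beyond the scatter), so a high number here does not depend on pentylsulfanyl, and losing that group did not bring the fall that the earlier compounds suggested. Against pentylsulfanyl itself the result reads an at least 1.7-fold higher number from compound 3 to compound 4 (0.23 log units; that floor lies within the scatter), a floor within the scatter. The compounds shown leave open how far compound 4 lies past its limit. They also leave open whether the amino nitrogen or the allyl double bond matters, which a propylamino or dimethylamino group could separate.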